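From 2-methoxyphenyl to 4-methoxyphenyl in an antiproliferative series

A few compounds are considered here, and "the series" means these few. Any claim that something is new, unique, unknown or untested is made for them only; others in the source may bear on it.

In a functional assay on MCF7 cells (Homo sapiens) for antiproliferative activity (a higher number here means a weaker inhibitor, a lower number a stronger inhibitor), compound 1 `N#CN(C(=N)NCCCCCOc1ccccc1)c1ccncc1` gives 150 nM and compound 2 `N#CN/C(=N\CCCCCCOc1ccccc1)Nc1cccnc1` gives 230 nM. Compound 3 `COc1ccccc1OCCCCCC/N=C(\NC#N)Nc1ccncc1` gives 1.1 nM, the lowest of the three numbers and beyond the scatter from both others. Compound 4 `COc1ccc(OCCCCCC/N=C(\NC#N)Nc2ccncc2)cc1` has the same atoms joined differently: 4-methoxyphenyl in place of 2-methoxyphenyl on an oxygen on a saturated carbon, with 4-methoxyphenyl in place of 2-methoxyphenyl on an oxygen on a saturated carbon. Among the compounds with values here, no measured pair isolates this change, so the expectation is tentative. Within the data shown here, with compound 3 at 1.1 nM as the lowest value so far, a modest weakening in this assay is expected. The expected change is a 2.7-fold higher number from compound 3 to compound 4 (0.44 log units; beyond the scatter). Compound 4 is estimated at 3 nM, with an expected range of 0.7 nM to 15 nM.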

Compound 4, half-maximal inhibitory concentration: 37 nM
For compound 4 the middle estimate is 12-fold (1.09 log units) below the measured one; measured number above the stated range.
By their numbers in this assay, from the lowest: compound 3; then compound 4; then compounds 1 and 2 (each within the scatter of the next).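

In this assay, 4-methoxyphenyl in place of 2-methoxyphenyl on an oxygen on a saturated carbon gives a 34-fold higher number from compound 3 to compound 4 (1.53 log units; beyond the scatter). At this position, then, a large step beyond the scatter arises with the same atoms joined differently, and 2-methoxyphenyl carries the lower number of the pair. Nothing available explains this step.

Still open, from the compounds shown here alone, is how 3-methoxyphenyl or 2-chlorophenyl would compare at this position. The compounds shown also give no one-place comparison with unsubstituted phenyl, so the contribution of the methoxy group itself remains unresolved.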